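A few compounds are considered here, and "the series" means these few. Any claim that something is new, unique, unknown or untested is made for them only; others in the source may bear on it.

Compound 2 `COc1ccc(NC(=O)C(=O)c2cn(CC3CCCO3)c3ccccc23)cn1` and compound 1 `COc1ccc(NC(=O)C(=O)c2cn(CCOC(C)C)c3ccccc23)cn1` share one core and differ only in the group bound to the aromatic nitrogen. In an ADME assay on liver (Mus musculus, strain CD-1) for metabolic stability, read by LC-MS, using microsomes and NADPH, with a stated time of 5 min, tested at 1 uM (a higher number here means that the compound lasts longer, a lower number that the compound disappears faster), compound 2 gives 0.567 h, and compound 1 gives 0.383 h. Going by the values given here, the only step between measured compounds, a 1.5-fold higher number from compound 1 to compound 2 (0.17 log units; within the scatter), is within the scatter, so the two numbers cannot be told apart with confidence; compound 2 simply stands with the largest of the two values recorded.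

Compound 3 `COCC(C)(C)n1cc(C(=O)C(=O)Nc2ccc(OC)nc2)c2ccccc21` is the next member of the set, not yet measured in this assay. It differs from compound 2 in one place: 1-(methoxymethyl)-1-methylethyl in place of (oxolan-2-yl)methyl on an aromatic nitrogen.

Among the compounds with values here, the one measured step bears on this change only loosely, since it also exchanged a ring-bearing chain for an open chain at the same aromatic nitrogen and produced nothing beyond the scatter. On that basis the step expected for compound 3 is a 1.1-fold lower number from compound 2 to compound 3 (0.05 log units; within the scatter), with no clear direction. Compound 3 is therefore estimated to give about 0.5 h, with a likely range from 0.25 h to 1 h.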

Compound 3, half-life: 0.267 h
The estimate for compound 3 lay 1.9-fold (0.27 log units) above the measured number, within the range that was stated.
By their numbers in this assay, from the lowest: compounds 3, 1 and 2 (each within the scatter of the next, the first and the last beyond it).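

In this assay, going by these compounds alone, putting 1-(methoxymethyl)-1-methylethyl in place of (oxolan-2-yl)methyl on the aromatic nitrogen gives the first step at this position to pass beyond the scatter, though only modestly (a 2.1-fold lower number from compound 2 to compound 3 (0.33 log units; beyond the scatter)). Within the data shown here, the same group in place of 2-isopropoxyethyl stays within the scatter (a 1.4-fold lower number from compound 1 to compound 3 (0.16 log units; within the scatter)), so compound 3 and compound 1 cannot be told apart, and compound 1, with its open chain, cannot be told apart from compound 2 either; the absence of a ring therefore does not by itself set a group apart, and only the pair of compound 2 and compound 3 is separated. No supporting information bears on why this one exchange reaches beyond the scatter.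

The compounds shown leave open whether the step to compound 3 follows from losing the ring or from the branching of the new chain, as the two changes arrive together. As far as these compounds go, all three groups carry an ether oxygen, so it also remains open how an amine, a carboxylic acid or a plain butyl chain on the aromatic nitrogen would stand in this assay.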